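From 4-ethylpiperazin-1-yl to (methoxycarbonyl)amino: expected cytotoxicity

This account rests on a few compounds, and the source may have more. Where it says the series, first, only, none or still open, it means among the compounds named here.

Compound 1 `CCN1CCN(C[C@H]2CN(c3ccc(-n4cc(-c5ccccn5)cn4)c(F)c3)C(=O)O2)CC1`: in an ADME assay on L02 cells (Homo sapiens) for cytotoxicity, read by MTT assay, with a stated time of 48 h (on this read-out lower numbers stand for stronger inhibition and higher numbers for weaker inhibition), compound 1 gives 99 ug/mL.
Compound 2 `COC(=O)CC1CCN(C[C@H]2CN(c3ccc(-n4cc(-c5ccccn5)cn4)c(F)c3)C(=O)O2)CC1`: in this assay compound 2 reaches only the limit > 400 ug/mL.
Compound 3 `CS(=O)(=O)NC[C@H]1CN(c2ccc(-n3cc(-c4ccccn4)cn3)c(F)c2)C(=O)O1`: in this assay compound 3 likewise reaches only the limit > 400 ug/mL.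

Among the three results, compound 1 carries the only actual number; the other two sit at the limit of > 400 ug/mL in this assay, at which 2 of the 3 values shown sit.

Compound 4 `COC(=O)NC[C@H]1CN(c2ccc(-n3cc(-c4ccccn4)cn3)c(F)c2)C(=O)O1` has not been measured. It differs from compound 1 in one place: (methoxycarbonyl)amino in place of 4-ethylpiperazin-1-yl on a saturated chain carbon bound to a saturated ring carbon. Two measured steps start from compound 1 and replace the same group on the same saturated chain carbon, and both end at the limit: an at least 4.0-fold higher number from compound 1 to compound 2 (0.60 log units; beyond the scatter) and an at least 4.0-fold higher number from compound 1 to compound 3 (0.60 log units; beyond the scatter). Neither of those exchanges kept the number of compound 1, so the same kind of move is expected here. Compound 4 is therefore expected to show a 4.0-fold higher number from compound 1 to compound 4 (0.61 log units; beyond the scatter). Compound 4 is estimated at 400 ug/mL, within a range from 150 ug/mL to 900 ug/mL, and may well be reported only as a limit.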

Compound 4, half-maximal inhibitory concentration: 71 ug/mL
Estimate against measurement, compound 4: 5.6-fold (0.75 log units) above, outside the stated range (below it).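

In this assay, removing 4-ethylpiperazin-1-yl from this saturated chain carbon does not in itself move the number, since the exchange for (methoxycarbonyl)amino stays within the scatter (a 1.4-fold lower number from compound 1 to compound 4 (0.14 log units; within the scatter)). The group on the amine nitrogen matters instead: methoxycarbonyl and methylsulfonyl, exchanged at that single place, give clearly different results (an at least 5.6-fold lower number from compound 3 to compound 4 (0.75 log units; beyond the scatter)). Compound 4 is likewise separated from the piperidine compound (an at least 5.6-fold lower number from compound 2 to compound 4 (0.75 log units; beyond the scatter)), so a high number does not follow from losing the piperazine ring.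

From the compounds shown here alone, whether an acetyl group or a free amine on the same chain carbon would sit with compound 4 or with the higher results stays open. Compound 2 and compound 3 stand only as limits, so the step between them cannot be read: the limit of > 400 ug/mL in this assay, at which 2 of the 4 values shown sit.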